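The source may report more compounds than this note shows. Statements on the series, on what has been measured and on what is new or still open speak of the compounds shown alone.

Measured in a functional assay on A549 cells (Homo sapiens) for inhibition, read by MTT assay, with a stated time of 72 h; on this read-out lower numbers stand for stronger inhibition and higher numbers for weaker inhibition:
- Compound 1 `Nc1ncnc2c1c(-c1cnc3[nH]ccc3c1)nn2CC(=O)NO`: > 150000 nM, a limit of the assay and not a number
- Compound 2 `Nc1ncnc2c1c(-c1cnc3[nH]ccc3c1)nn2CCCCCCCCCC(=O)NO`: 6550 nM

For the measured compounds named here, compound 2, at 6550 nM, holds the only number. The other result is a limit: the limit of > 150000 nM in this assay, at which 1 of the 2 values shown sits.

The next compound to consider is compound 3 `Nc1ncnc2c1c(-c1cnc3[nH]ccc3c1)nn2CCCC(=O)NO`, which keeps the shared core and the terminal hydroxycarbamoyl but carries a shorter chain than compound 2. The change is hydroxycarbamoyl in place of 6-(hydroxycarbamoyl)hexyl on a saturated chain carbon, three bonds along the chain from an aromatic nitrogen.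

Going by the values given here, no measured step isolates this change, so the expectation rests on the two results alone. Compound 1, whose chain is shorter still, gives > 150000 nM, which is a limit. The expected change in this assay is a weakening beyond the scatter, estimated as a 7.6-fold higher number from compound 2 to compound 3 (0.88 log units; beyond the scatter). For compound 3 the estimated value is 50000 nM, with an expected range of 15000 nM to 150000 nM.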

Compound 3, half-maximal inhibitory concentration: > 150000 nM
Compound 3: only a limit was reported; the forecaster's own chance of this, stated with the estimate: 35%; middle value at least 3.0-fold (0.47 log units) from the limit.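

In this assay, hydroxycarbamoyl in place of 6-(hydroxycarbamoyl)hexyl on a saturated chain carbon, three bonds along the chain from an aromatic nitrogen, gives an at least 22-fold higher number from compound 2 to compound 3 (1.35 log units; beyond the scatter), so the length of the chain at this position carries a large part of the inhibition seen in this series. As far as these compounds go, compound 3 gives > 150000 nM, a limit of the assay and not a number, so the true size of this step stays open and only its lower bound is known. Compound 1 and compound 3 both stand at the limit, and the step between them cannot be read: the limit of > 150000 nM in this assay, at which 2 of the 3 values shown sit.

Open, from the compounds shown here alone, is where the inhibition first becomes measurable on going from the chain of compound 3 to that of compound 2, and whether a longer chain than that of compound 2 brings the number further down. Also open, going by these compounds, is whether a carboxylic acid or a primary amide at the chain end, in place of the terminal hydroxycarbamoyl, would hold the level of compound 2 at 6550 nM.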